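A few compounds are considered here, and "the series" means these few. Any claim that something is new, unique, unknown or untested is made for them only; others in the source may bear on it.

In a functional assay on HEK293 cells with D(4) dopamine receptor (Homo sapiens) as the target, read by FLIPR (a higher number here means that more compound is needed for the effect, a lower number that less compound is needed), the three measured compounds gave:
compound 1, `O/N=C(/CCN1CCN(c2ccccn2)CC1)c1ccccc1`: 21.7 nM
compound 2, `O/N=C(\CCN1CCN(c2ccccn2)CC1)c1cccc(Cl)c1`: 11.9 nM
compound 3, `O/N=C(/CCN1CCN(c2ccccn2)CC1)c1cc(F)cc(F)c1`: 17.5 nM

Compound 2 sits at the low end of these three numbers, yet compound 3 and compound 1 both lie within the usual scatter of it. Compound 4, `O/N=C(\CCN1CCN(c2ccccn2)CC1)c1ccc(F)cc1F`, differs from compound 2 by 2,4-difluorophenyl in place of 3-chlorophenyl on a carbon with a double bond to nitrogen. Within the data shown here, the one measured step that bears on swapping substituents on this ring, a 1.2-fold lower number from compound 1 to compound 3 (0.09 log units; within the scatter), stayed within the scatter, and compound 1 and compound 2 show values within the scatter of each other. Compound 4 is therefore expected to show no change beyond the scatter, with a 1.4-fold higher number from compound 2 to compound 4 (0.15 log units; within the scatter). The estimate for compound 4 in this assay is 17 nM, ranging from 7 nM to 40 nM.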

Compound 4, half-maximal effective concentration: 8.9 nM
Beside the measured number, compound 4's estimate is 1.9-fold (0.28 log units) above it, and the stated range covers the measured number.
By their numbers in this assay, from the lowest: compounds 4, 2, 3 and 1 (each within the scatter of the next, the first and the last beyond it).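

In this assay the exchange on the carbon with a double bond to nitrogen gives a 1.3-fold lower number from compound 2 to compound 4 (0.13 log units; within the scatter) and so this position takes 2,4-difluorophenyl about as well as 3-chlorophenyl. The earlier step only added fluorine to a plain phenyl, whereas this one replaces chlorine with two fluorines and still stays within the scatter. Nothing shown explains why these rings read alike.

Still open, from the compounds shown here alone, is how this position responds to a ring carrying a methoxy group or a trifluoromethyl group, or to a pyridine in place of the phenyl ring.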